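Swapping sulfur for selenium on a nitro-thiophene pair

The source may hold more compounds than are shown below. What is called first, only, known or untested is meant among the compounds shown, and "the series" means these compounds.

Measured so far:
compound 1, `C[Se]/C(=N\C(=O)c1cc2ccccc2s1)NC(=O)c1cc2ccccc2s1`: 37200 nM
compound 2, `CS/C(=N\C(=O)c1csc([N+](=O)[O-])c1)NC(=O)c1csc([N+](=O)[O-])c1`: 41500 nM
compound 3, `C[Se]/C(=N\C(=O)c1sccc1Cl)NC(=O)c1sccc1Cl`: 970 nM

Of the compounds shown here, three have been tested in a functional assay on PC-3 cells (Homo sapiens) for cytotoxicity, read by MTT assay, with a stated time of 72 h (on this read-out higher numbers stand for weaker inhibition of growth and lower numbers for stronger inhibition of growth), and all share the same central arrangement: a carbon doubly bonded to nitrogen, carrying two amide-type nitrogens, each of which bears a thiophene-containing acyl group. In this assay compound 2 gives 41500 nM, the highest of the three numbers. Compound 1 gives 37200 nM, a number that sits within the usual scatter of compound 2, so the two cannot be told apart. Compound 3 gives 970 nM, a number well below that of compound 2 and beyond the scatter, so compound 3 inhibits growth more strongly than compound 2.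

Compound 4, `C[Se]/C(=N\C(=O)c1csc([N+](=O)[O-])c1)NC(=O)c1csc([N+](=O)[O-])c1`, has not yet been measured. It differs from compound 2 in one place: a group of 2 heavy atoms (1 carbon, 1 selenium; no ring) in place of a group of 2 heavy atoms (1 carbon, 1 sulfur; no ring), on a carbon with a double bond to nitrogen. For the measured compounds named here, both compound 1 and compound 3 already carry this selenium group, but each sits on a different thiophene substitution, so no measured pair isolates the sulfur-to-selenium swap on its own.

With nothing directly comparable, the expected step in this assay from compound 2 to compound 4 is small, a 1.3-fold lower number from compound 2 to compound 4 (0.11 log units; within the scatter), with no clear direction beyond the scatter. Compound 4 is estimated at 32000 nM, with a plausible range from 8000 nM to 130000 nM.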

Compound 4, concentration for 50% growth inhibition: 100 nM
Beside the measured number, compound 4's estimate is 320-fold (2.51 log units) above it, and the stated range ends above it.
By their numbers in this assay, from the lowest: compound 4; then compound 3; then compounds 1 and 2 (each within the scatter of the next).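

Exchanging the methylsulfanyl group for its selenium counterpart, on a carbon with a double bond to nitrogen, gives a 420-fold lower number from compound 2 to compound 4 (2.62 log units; beyond the scatter) in this assay, while the rest of the molecule stays the same. Compounds 1 and 3 could not show this, as each also differs from compound 2 in its acyl groups; this pair shows that a single atom at this place, in a group of the same size by heavy-atom count, can by itself separate a weak growth inhibitor from a strong one. Nothing available explains why selenium has so much larger an effect here than sulfur, so the size of the step remains an observation without a known cause.

The compounds shown leave open whether the swap has a similar effect with other acyl groups, as neither compound 1 nor compound 3 has a sulfur partner here. They also leave open how much this place tolerates other groups, such as an ethyl chain on the selenium or an amine in place of the whole group.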